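A few compounds are considered here, and "the series" means these few. Any claim that something is new, unique, unknown or untested is made for them only; others in the source may bear on it.

Compound 1, `Cn1cc2c(Cl)nc(NC(=O)c3ccccc3)nc2n1`, in a functional assay on CHO cells for antagonist activity at adenosine receptor A2b (Homo sapiens), read by 33P incorporation, with a stated time of 20 min, in the presence of a further agent that is not named here (a higher number here means a weaker inhibitor, a lower number a stronger inhibitor), gives > 20000 nM, which is a limit of the assay rather than a number.
Compound 2, `Cn1cc2c(Cl)nc(NC(=O)c3ccc(C(F)(F)F)cc3)nc2n1`, in this assay gives > 20000 nM, again a limit of the assay.

Compound 2 therefore stands at the edge of what this assay can read, as shown by the limit of > 20000 nM in this assay, at which 2 of the 2 values shown sit. Among the measured compounds shown here, the only measured step, a step that the two limits leave unreadable from compound 1 to compound 2, cannot be sized. Compound 3, `Cn1cc2c(Cl)nc(NC(=O)c3ccc(F)cc3)nc2n1`, differs from compound 2 by fluoro in place of trifluoromethyl on an aromatic carbon. For the measured compounds named here, no measured step bears on this change, so neither a direction nor a size can be read from the data. Compound 3 is expected to stay near the limit, with an estimated step that the limit leaves unreadable from compound 2 to compound 3, giving an estimate of 30000 nM with a range from 8000 nM to 100000 nM.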

Compound 3, inhibition constant: > 20000 nM
Compound 3: a limit, no number; the forecaster's own chance of this, stated with the estimate: 85%; the middle value lies beyond the limit too.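

No step among compound 1, compound 2 and compound 3 can be read, since all three sit at the same limit: the limit of > 20000 nM in this assay, at which 3 of the 3 values shown sit.

The compounds shown leave open how strong an inhibitor each one is, and whether changing the group on the aromatic ring matters at all.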